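Nitrile to methoxymethyl on a piperidine amide scaffold

The source may report more compounds than this note shows. Statements on the series, on what has been measured and on what is new or still open speak of the compounds shown alone.

The series shares a piperidine core carrying two amides, one to an aniline and one to a benzoyl group. Compound 1 `Cc1nc(-c2cccc(NC(=O)C3CCCN(C(=O)c4cc(C(F)(F)F)cc(C(F)(F)F)c4)C3)c2)cs1` gives 1% in an ADME assay on PC-3 cells (Homo sapiens) for cytotoxicity, read by WST assay, tested at 100 uM (on this read-out lower numbers stand for less inhibition and higher numbers for more inhibition at the one concentration tested (going by the name of the read-out)), and compound 3 `CC(=O)c1cccc(NC(=O)C2CCCN(C(=O)c3cc(C(F)(F)F)cc(C(F)(F)F)c3)C2)c1` gives 0%; the step of a number 1 percentage points lower from compound 1 to compound 3 (within the scatter) stays within the scatter. Compound 2 `N#Cc1cccc(C(=O)N2CCCC(C(=O)Nc3ccc(Cl)cc3)C2)c1` gives 0%, level with compound 3 at the digits shown and together with it the lowest of the three numbers, while compound 1 sits higher by an amount inside the scatter. All three compounds therefore show essentially no inhibition at the single concentration tested.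

Compound 4 `COCc1cccc(C(=O)N2CCCC(C(=O)Nc3ccc(Cl)cc3)C2)c1` differs from compound 2 by methoxymethyl in place of cyano on an aromatic carbon. Within the data shown here, none of the measured steps touches this benzoyl position; the only measured step, from compound 1 to compound 3, concerns the aniline side and was within the scatter. With every measured value at the floor of the read-out, compound 4 is expected to show no step beyond the scatter, a number 1 percentage points higher from compound 2 to compound 4 (within the scatter). The estimate for compound 4 in this assay is 1%, with a range from -8% to 12%.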

Compound 4, a percentage reported as inhibition, at one concentration (the size of the read-out at that concentration, not a potency): 0%
Compound 4: middle estimate off by 1 percentage points, on the high side; the measured number falls inside the stated range.
By their numbers in this assay, from the lowest: compounds 2, 3, 4 and 1 (each within the scatter of the next).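

Among these compounds, this is the first measured change on the benzoyl side of the series, where the earlier step concerned only the aniline side. In this assay, exchanging 3-cyanophenyl for 3-(methoxymethyl)phenyl gives no change at the digits printed from compound 2 to compound 4 (within the scatter), so losing the nitrile with its triple bond and bringing in an ether oxygen on a slightly larger group leaves the read-out where it was. Nothing available explains this result.

Because both compounds read close to zero, the pair cannot show whether this aromatic carbon matters at all for the read-out, or whether methoxymethyl and cyano would also match in a compound with a higher number. On these data alone, it remains open whether a carboxylic acid or an aminomethyl group on the same carbon would move the number beyond the scatter.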